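Swapping cyano for (piperidin-3-yl)carbamoyl

This account rests on a few compounds, and the source may have more. Where it says the series, first, only, none or still open, it means among the compounds named here.

Compound 1 `Cn1cc(-c2cc(F)c3ncc(Cc4ccc5ncccc5c4)n3c2)cn1` gives 0.27 nM
Compound 2 `N#Cc1ccc(-c2cc(F)c3ncc(Cc4ccc5ncccc5c4)n3c2)cc1F` gives 145 nM
Compound 3 `CNC(=O)c1cccc(-c2cc(F)c3ncc(Cc4ccc5ncccc5c4)n3c2)c1` gives 400 nM

In a functional assay on EBC-1 cells (Homo sapiens) for antiproliferative activity, with a stated time of 72 h (on this read-out lower numbers stand for stronger inhibition and higher numbers for weaker inhibition), compound 2 gives 145 nM as the second highest of the three numbers. The gap down to the lowest is a 540-fold higher number from compound 1 to compound 2 (2.73 log units; beyond the scatter) and the gap up to the highest is a 2.8-fold higher number from compound 2 to compound 3 (0.44 log units; beyond the scatter) in this short series.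

Compound 4 `O=C(NC1CCCNC1)c1ccc(-c2cc(F)c3ncc(Cc4ccc5ncccc5c4)n3c2)cc1F` has not yet been measured. Set against compound 2 it shows (piperidin-3-yl)carbamoyl in place of cyano on an aromatic carbon on the carbon that held the cyano group, ortho to a fluoro group and para to a large group.

The large steps of a 540-fold higher number from compound 1 to compound 2 (2.73 log units; beyond the scatter) and a 1500-fold higher number from compound 1 to compound 3 (3.17 log units; beyond the scatter) both replace the 1-methyl-1H-pyrazol-4-yl group, a change that does not separate compound 2 from compound 4. The nearer guide is compound 3, which also carries a carbamoyl group, and the step of a 2.8-fold higher number from compound 2 to compound 3 (0.44 log units; beyond the scatter) is only modest. A step no larger than that one is therefore expected in this assay with a slight lean towards a higher number. Among the compounds with values here, no measured compound carries the (piperidin-3-yl)carbamoyl group, which leaves the expectation uncertain. The estimated step is a 1.4-fold higher number from compound 2 to compound 4 (0.14 log units; within the scatter) and it would remain small. For compound 4 the estimated value is 200 nM with 40 nM to 900 nM as the expected range.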

Compound 4, half-maximal inhibitory concentration: 138 nM
The estimate for compound 4 lay 1.4-fold (0.16 log units) above the measured number; low and high end bracket the measured number.
By their numbers in this assay, from the lowest: compound 1; then compounds 4 and 2 (each within the scatter of the next); then compound 3.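

In this assay, putting (piperidin-3-yl)carbamoyl in place of cyano gives a 1.1-fold lower number from compound 2 to compound 4 (0.02 log units; within the scatter), so compound 2 and compound 4 cannot be told apart on this read-out. The earlier compounds shown here had not tested this carbon on its own, ortho to a fluoro group and para to a large group; here it carries 9 heavy atoms, a six-membered non-aromatic ring and 2 hydrogen-bond donors instead of a 2-atom nitrile with no donors, and the antiproliferative read-out stays within the usual scatter. Nothing available here accounts for that outcome, and the result describes this one exchange only.

The compounds shown leave open whether the piperidine ring contributes anything of its own, a question that a plain methylcarbamoyl group on this same carbon, an open-chain aminoethyl amide or a carboxylic acid could address. They also leave open whether the fluoro group plays any part in this result, which a matching compound with hydrogen on that carbon would show.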